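The compounds below may be only part of what the source reports. "The series", "measured", "known", "first", "only" and "open" are said of these compounds alone.

In a functional assay on cells (Platelet, Homo sapiens) for inhibition (on this read-out higher numbers stand for weaker inhibition and lower numbers for stronger inhibition), compound 1 (`CCOC(=O)c1ccc(-c2nn(-c3ccco3)c3ccccc23)cc1`) gives > 10000 nM as a limit. Compound 2 (`CCOC(=O)c1ccc(-c2nn(-c3ccoc3)c3ccccc23)cc1`) gives > 10000 nM as a limit too, so it offers no number to start from. The record so far is only this: the limit of > 10000 nM in this assay, at which 2 of the 2 values shown sit, for the series. Going to compound 3 (`CCCn1nc(-c2ccc(C(=O)OCC)cc2)c2ccccc21`) means propyl in place of furan-3-yl on an aromatic nitrogen. For the measured compounds named here, the one measured step, a step that the two limits leave unreadable from compound 1 to compound 2 in size, gives no magnitude to carry over. No step beyond the scatter is therefore expected, in either direction, and the expected step is a number no higher from compound 2 to compound 3 (the limit leaves the size open) on this basis. Compound 3 is estimated at 10000 nM with a range of 3000 nM to 30000 nM in this read-out.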

Compound 3, half-maximal inhibitory concentration: > 10000 nM
Compound 3: only a limit was reported; the forecaster's own chance of this, stated with the estimate: 75%; the middle value sits exactly at the limit.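

No new step can be read among compound 1, compound 2 and compound 3, as all remain limits: the limit of > 10000 nM in this assay, at which 3 of the 3 values shown sit.

On these data alone, whether furan-2-yl, furan-3-yl and propyl on an aromatic nitrogen differ in inhibition at all remains open.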